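Leaving the Ring Stereocentre Undefined

The compounds below may be only part of what the source reports. "The series", "measured", "known", "first", "only" and "open" are said of these compounds alone.

In an assay on HEK293 cells for inhibition of sodium- and chloride-dependent glycine transporter 1 (Homo sapiens) (a higher number here means a weaker inhibitor, a lower number a stronger inhibitor), compound 3 `CC[C@H]1CCCCN1C[C@@H](O)CNS(=O)(=O)c1cccc2ccccc12` gives 100 nM, the lowest of the three numbers measured. Compound 1 `CCC1CCC(C)N(C[C@@H](O)CNS(=O)(=O)c2cccc3ccccc23)C1` gives 1000 nM and compound 2 `CCCN(C[C@@H](O)CNS(=O)(=O)c1cccc2ccccc12)C(C)(C)C` gives 1000 nM. The steps into compound 3 were both beyond the scatter: a 10-fold lower number from compound 1 to compound 3 (1.00 log units; beyond the scatter) and a 10-fold lower number from compound 2 to compound 3 (1.00 log units; beyond the scatter), while no change at the digits printed from compound 1 to compound 2 (within the scatter). Compound 4 `CCC1CCCCN1C[C@@H](O)CNS(=O)(=O)c1cccc2ccccc12` differs from compound 3 only in this: the two compounds have the same atoms and bonds; at least one stereo element is drawn with a configuration in one of them and without one in the other: 1 of 2 stereo elements differ; a stereocentre at a saturated ring carbon is drawn S in compound 3 and without a configuration in compound 4. Going by the values given here, none of the measured steps changes a stereo element alone, so they give no direct guide; the only anchor is that compound 3 holds the lowest number and compound 4 keeps the same atoms and bonds. If the undefined centre only partly carries the configuration of compound 3, a small loss is expected. The expected step is therefore a 1.6-fold higher number from compound 3 to compound 4 (0.20 log units; within the scatter). Compound 4 is estimated at 160 nM, between 70 nM and 400 nM.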

Compound 4, half-maximal inhibitory concentration: 7940 nM
Compound 4: the middle estimate sits 50-fold (1.70 log units) below what was measured, outside the stated range (above it).
By their numbers in this assay, from the lowest: compound 3; then compounds 1 and 2 (each within the scatter of the next); then compound 4.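

In this assay, leaving the ring carbon without a configuration, with atoms and bonds unchanged, gives a 79-fold higher number from compound 3 to compound 4 (1.90 log units; beyond the scatter). The 2-ethylpiperidin-1-yl group alone therefore does not secure the low number, since in this undefined form the comparisons run the other way: a 7.9-fold higher number from compound 2 to compound 4 (0.90 log units; beyond the scatter) and a 7.9-fold higher number from compound 1 to compound 4 (0.90 log units; beyond the scatter). The large step rests on a single difference: the fact that one of compounds 3 and 4 is drawn with a defined configuration and the other without, at the place where they differ

As far as these compounds go, how the opposite configuration at this ring carbon behaves remains open. So does whether a 2-propylpiperidin-1-yl group would depend on its configuration in the same way.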